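This account rests on a few compounds, and the source may have more. Where it says the series, first, only, none or still open, it means among the compounds named here.

Measured so far in an assay on Prostate gland for inhibition of steroid 5-alpha-reductase (Rattus norvegicus); on this read-out lower numbers stand for stronger inhibition and higher numbers for weaker inhibition:

Compound 1, `C/C(=C\C(=O)Nc1ccccc1OCCCC(=O)O)c1ccc2c(ccn2CC(C)C)c1`: in this assay compound 1 gives 160 nM.
Compound 2, `CC(C)=CCn1ccc2cc(/C(C)=C/C(=O)Nc3ccccc3OCCCC(=O)O)ccc21`: in this assay compound 2 gives 120 nM.
Compound 3, `CCCC(C)n1ccc2cc(/C(C)=C/C(=O)Nc3ccccc3OCCCC(=O)O)ccc21`: in this assay compound 3 gives 7.8 nM.

Compound 3 holds the lowest number of the three, and both of its steps lie beyond the scatter: a 21-fold lower number from compound 1 to compound 3 (1.31 log units; beyond the scatter) and a 15-fold lower number from compound 2 to compound 3 (1.19 log units; beyond the scatter). It is therefore the strongest inhibitor among the measured compounds. Compound 1 and compound 2, by contrast, sit within the scatter of each other: a 1.3-fold lower number from compound 1 to compound 2 (0.12 log units; within the scatter).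

Compound 4, `CCCCCC(CCCCC)n1ccc2cc(/C(C)=C/C(=O)Nc3ccccc3OCCCC(=O)O)ccc21`, has not been measured yet. It differs from compound 3 in one place: 1-pentylhexyl in place of 1-methylbutyl on an aromatic nitrogen. The two large steps described above both exchanged a shorter group on that same nitrogen for 1-methylbutyl and lowered the number sharply, so the size of the group on this nitrogen clearly matters in this assay. For the measured compounds named here, no measured step, however, goes beyond 1-methylbutyl, so whether a much longer branched chain helps further or reverses the gain cannot be read from these three compounds. The expectation is therefore centred near compound 3 with a wide range.

Compound 4 is expected to give 15 nM, with a range from 3 nM to 100 nM. This estimate amounts to an expected step of a 1.9-fold higher number from compound 3 to compound 4 (0.28 log units; within the scatter).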

Compound 4, half-maximal inhibitory concentration: 25 nM
Beside the measured number, compound 4's estimate is 1.7-fold (0.22 log units) below it; the range from low to high includes it.
By their numbers in this assay, from the lowest: compound 3; then compound 4; then compounds 2 and 1 (each within the scatter of the next).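

In this assay, giving both arms of the branch more carbon, as 1-pentylhexyl does, costs some strength (a 3.2-fold higher number from compound 3 to compound 4 (0.51 log units; beyond the scatter)), so among the groups shown on this aromatic nitrogen the number does not keep falling as the chain grows. Much of the earlier gain survives even so, for 1-pentylhexyl still gives lower numbers than 3-methylbut-2-en-1-yl (a 4.8-fold lower number from compound 2 to compound 4 (0.68 log units; beyond the scatter)) and isobutyl (a 6.4-fold lower number from compound 1 to compound 4 (0.81 log units; beyond the scatter)), and with no compound going against it, the two groups branched at their first carbon, 1-methylbutyl and 1-pentylhexyl, hold the two lowest numbers of the four. No measurement here bears on why these groups differ in this way.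

From the compounds shown here alone, what stays open is where the best chain lies between 1-methylbutyl and 1-pentylhexyl, since a group such as 1-propylbutyl could fall on either side of compound 3. Equally open, going by these compounds, is how a cyclopentyl ring, or a chain ending in an amine, would fare on this same nitrogen.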